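Swapping Bromine for Trifluoromethyl on a Piperazine Amide

A few compounds are considered here, and "the series" means these few. Any claim that something is new, unique, unknown or untested is made for them only; others in the source may bear on it.

Compound 1, `COC(=O)c1coc(CN2CCN(C(=O)CC(c3ccccc3)c3ccc(Br)cc3)CC2)n1`, is tested in an assay on HEK293 cells for inhibition of Voltage-dependent T-type calcium channel subunit alpha-1G (Homo sapiens) (a lower number here means a stronger inhibitor, a higher number a weaker inhibitor), where compound 1 gives 21200 nM. Within the data shown here, that is the higher of the two numbers measured so far: compound 2, `COC(=O)c1coc(CN2CCN(C(=O)CC(c3ccc(F)cc3)c3ccc(Br)cc3)CC2)n1`, gives 860 nM. Among the measured compounds shown here, the only measured step, a 25-fold lower number from compound 1 to compound 2 (1.39 log units; beyond the scatter), comes from a change elsewhere in the molecule and leaves the bromine untouched. Compound 3, `COC(=O)c1coc(CN2CCN(C(=O)CC(c3ccccc3)c3ccc(C(F)(F)F)cc3)CC2)n1`, differs from compound 1 by trifluoromethyl in place of bromo on an aromatic carbon. For the measured compounds named here, no measured step shows what this particular exchange does, so the expectation rests on compound 1 alone and carries wide uncertainty. For compound 3 the estimated step is a 1.5-fold lower number from compound 1 to compound 3 (0.18 log units; within the scatter), small and not beyond the scatter. The estimate for compound 3 in this assay is therefore 14000 nM, with a range from 3500 nM to 56000 nM.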

Compound 3, half-maximal inhibitory concentration: 17100 nM
For compound 3 the middle estimate is 1.2-fold (0.09 log units) below the measured one; the range from low to high includes it.
By their numbers in this assay, from the lowest: compound 2; then compounds 3 and 1 (each within the scatter of the next).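

In this assay, putting trifluoromethyl where bromo stood gives a 1.2-fold lower number from compound 1 to compound 3 (0.09 log units; within the scatter), so compounds 1 and 3 cannot be told apart in this assay. The earlier step came from a change elsewhere in the molecule, whereas this one tests the bromine site itself: on this aromatic carbon, four heavy atoms can replace one without the number shifting beyond the scatter. No measurement of any property of these compounds bears on this result, so no cause can be given for it.

On these data alone, it remains open whether the same exchange would also leave the number in place on compound 2, which carries the fluoro group. Also open, as far as these compounds go, is how this position would respond to a quite different group, such as an amine, a carboxylic acid or a nitrile.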